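Moving a fluorine around the distal ring

This account rests on a few compounds, and the source may have more. Where it says the series, first, only, none or still open, it means among the compounds named here.

Measured compounds:
Compound 1, `O=C(Nc1ccc(F)c(-c2nc3ncc(-c4cccc(F)c4)cc3[nH]2)c1)N1CCCC1`: 0.0833 h
Compound 2, `O=C(Nc1ccc(F)c(-c2nc3ncc(-c4cc(F)cc(F)c4)cc3[nH]2)c1)N1CCCC1`: 0.128 h

Two compounds sharing one core have been run in an ADME assay on microsomes from liver (Mus musculus) for metabolic stability, read by LC-MS; on this read-out higher numbers stand for a longer-lived compound and lower numbers for a shorter-lived compound. Compound 1 gives 0.0833 h in this assay, and compound 2 gives 0.128 h. For the measured compounds named here, the one measured step, a 1.5-fold higher number from compound 1 to compound 2 (0.19 log units; within the scatter), places compound 2 alongside compound 1 rather than apart from it: the two numbers cannot be told apart on this read-out.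

Compound 3, `O=C(Nc1ccc(F)c(-c2nc3ncc(-c4ccc(F)c(F)c4)cc3[nH]2)c1)N1CCCC1`, has not yet been measured in this assay. It differs from compound 2 in one place: 3,4-difluorophenyl in place of 3,5-difluorophenyl on an aromatic carbon. Going by the values given here, the only measured step concerns adding a fluorine, not moving one, so it bears on this change only loosely; it shows that a fluorine change on that ring gave a 1.5-fold higher number from compound 1 to compound 2 (0.19 log units; within the scatter), a step that stayed within the scatter. With nothing pointing either way, compound 3 is expected to give a number near that of compound 2, with an estimated step of a 1.2-fold lower number from compound 2 to compound 3 (0.07 log units; within the scatter). The estimate for compound 3 in this assay is therefore 0.11 h, with a range from 0.05 h to 0.25 h.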

Compound 3, half-life: 0.08 h
Beside the measured number, compound 3's estimate is 1.4-fold (0.14 log units) above it; the measured number falls inside the stated range.
By their numbers in this assay, from the lowest: compounds 3, 1 and 2 (each within the scatter of the next).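

The swap of 3,5-difluorophenyl for 3,4-difluorophenyl on the shared core gives, in this assay, a 1.6-fold lower number from compound 2 to compound 3 (0.20 log units; within the scatter) and so stays within the usual scatter, which means that this arrangement of the two fluorines cannot be told apart on this read-out. Adding a fluoro to compound 1 to reach the 3,4-difluorophenyl group gives a 1.0-fold lower number from compound 1 to compound 3 (0.02 log units; within the scatter) and is also within the scatter, as was the earlier step to the 3,5-difluorophenyl group. Across these three compounds, then, no fluorine change on this ring separates one number from another, and nothing at hand explains why the numbers sit together.

The compounds shown carry only fluoro on this ring, so they leave open whether a different group there, such as a chloro, a methoxy or an amine, would give a step beyond the scatter. They also leave open how a plain phenyl with no fluorine at all would read in this assay when set against these three compounds.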